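A few compounds are considered here, and "the series" means these few. Any claim that something is new, unique, unknown or untested is made for them only; others in the source may bear on it.

Measured compounds:
compound 1 `CN1CCCN(CCn2ccc3ccc(Cl)cc32)CC1`, 85%
compound 2 `Brc1ccc2ccn(CCN3CCCNCC3)c2c1`, 77%

In an assay on HEK293 cells for binding affinity to 5-hydroxytryptamine receptor 7 (Homo sapiens), read by radioligand binding, tested at 1 uM (on this read-out higher numbers stand for more inhibition at the one concentration tested (going by the name of the read-out) and lower numbers for less inhibition), compound 1 gives 85%, and compound 2 gives 77%, the lower of the two numbers, though the gap to compound 1 lies within the scatter. Compound 3 `Brc1ccc2ccn(CCN3CCCN(C4CCCC4)CC3)c2c1` is not yet measured. It differs from compound 2 by cyclopentyl in place of hydrogen on an amine nitrogen in a ring. The two measured compounds show that the substituent on this amine nitrogen, hydrogen or methyl, leaves the result unchanged beyond the scatter. Compound 3 is therefore expected to give a step of a number 3 percentage points higher from compound 2 to compound 3 (within the scatter), with an estimated 80%, ranging from 55% to 95%.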

Compound 3, a percentage reported as inhibition, at one concentration (the size of the read-out at that concentration, not a potency): 98%
The estimate for compound 3 lay 18 percentage points below the measured number; the whole stated range lies below it.
By their numbers in this assay, from the lowest: compounds 2 and 1 (each within the scatter of the next); then compound 3.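

In this assay, cyclopentyl in place of hydrogen on the amine nitrogen in the ring gives a number 21 percentage points higher from compound 2 to compound 3 (beyond the scatter), so this nitrogen carries a five-membered carbon ring with a gain beyond the scatter. The earlier compounds shown here held only hydrogen or methyl here and differed elsewhere too, so they could not show this single change on its own. Nothing available here explains the gain.

As far as these compounds go, whether a cyclohexyl ring, a benzyl group or an open isopropyl chain on this nitrogen would give a similar step remains open. So does whether the step from cyclopentyl would hold with chlorine in place of bromine on the shared core.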